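The compounds below may be only part of what the source reports. "The series", "measured", "known", "first", "only" and "open" are said of these compounds alone.

Working notes on the series. Compound 1 `CN1CCN(c2ccc3c(c2)oc(=O)n3C(=O)NCCCCc2ccccc2)CC1=O` is run in an ADME assay on microsomes from liver (Mus musculus) for metabolic stability, read by LC-MS, using NADPH, with stated times of 15 min and 60 min, tested at 4.6 uM; on this read-out lower numbers stand for a shorter-lived compound and higher numbers for a longer-lived compound; there compound 1 gives 0.5 h. Compound 2 `CC(C)CNC(=O)n1c(=O)oc2cc(C3CCCN(C)C3)ccc21` returns in this assay a result of > 1 h, which is a limit of the assay and not a number. Compound 1 therefore stands as the only plain measured half-life in the set, while the other entry rests at the limit of > 1 h in this assay, at which 1 of the 2 values shown sits.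

The step from compound 1 to compound 3 `CCN1CCN(c2ccc3c(c2)oc(=O)n3C(=O)NCCCCc2ccccc2)CC1` is 4-ethylpiperazin-1-yl in place of 4-methyl-3-oxopiperazin-1-yl on an aromatic carbon. Among the measured compounds shown here, no step between two measured compounds is available to set the scale of such a change, so the expectation rests on the value of compound 1 alone. The change is expected to move the half-life little in this assay, with at most a slight lean toward a shorter-lived compound, and the move may well stay within the usual scatter. For compound 3 the expected half-life in this assay is 0.4 h, within 0.2 h and 0.9 h. The step this implies is expected to be a 1.3-fold lower number from compound 1 to compound 3 (0.10 log units; within the scatter).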

Compound 3, half-life: < 0.0834 h
Compound 3 ended at the assay's limit; the forecaster's own chance of this, stated with the estimate: 10%; at least 4.7-fold (0.68 log units) between middle value and limit.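

Among the compounds shown here, at this position, on an aromatic carbon of a six-membered aromatic ring of carbon only, 4-ethylpiperazin-1-yl in place of 4-methyl-3-oxopiperazin-1-yl gives the first single-change comparison in this assay, and the change is not a neutral one: it gives an at least 5.9-fold lower number from compound 1 to compound 3 (0.77 log units; beyond the scatter). Compound 3 sits at a limit of the assay and not at a number, so the step gives only a smallest size: the limit of < 0.0834 h in this assay, at which 1 of the 3 values shown sits. The two groups have the same ring size and the same heavy-atom count, and they part only in the carbonyl of the group that leaves and the ethyl of the group that enters, so the half-life at this position responds strongly to a change that leaves the size of the group as it was.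

The step joins these two differences, and the compounds shown do not separate them; a 4-methylpiperazin-1-yl group at the same place would set the carbonyl apart from the ethyl. What lies behind the step also stays open, and compound 2 differs from compound 1 and compound 3 in more than one place, so it offers no comparison here.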